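Aryl piperazine amides: dichlorophenyl replacing phenyl

The source may report more compounds than this note shows. Statements on the series, on what has been measured and on what is new or still open speak of the compounds shown alone.

Working notes on a small set of piperazine amides sharing one core. Compound 1 `Cc1nc(-c2ccccc2F)c(C(=O)N2CCN(c3cc(Cl)cc(Cl)c3)CC2)o1` carries a 3,5-dichlorophenyl on the piperazine nitrogen together with a 2-fluorophenyl on the core; in a functional assay on HL-60 cells (Homo sapiens) for inhibition, read by MTT assay, with a stated time of 72 h (a higher number here means a weaker inhibitor, a lower number a stronger inhibitor), compound 1 gives 60.2 nM. Compound 2 `Cc1nc(-c2ccccc2)c(C(=O)N2CCN(c3cccc(C#N)c3)CC2)o1` gives 39.6 nM in this assay, and compound 3 `Cc1nc(-c2ccccc2)c(C(=O)N2CCN(c3ccccc3)CC2)o1` gives 39.1 nM. Compound 3 has the lowest number of the three, but its gap to compound 2 and its gap to compound 1 both lie within the scatter, so no order can be read among them. For the measured compounds named here, the one single-point step, a 1.0-fold lower number from compound 2 to compound 3 (0.01 log units; within the scatter), is also within the scatter.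

Compound 4 `Cc1nc(-c2ccccc2)c(C(=O)N2CCN(c3cc(Cl)cc(Cl)c3)CC2)o1` differs from compound 3 by 3,5-dichlorophenyl in place of phenyl on an amine nitrogen in a ring. Going by the values given here, no measured step isolates this change; compound 1 carries the same 3,5-dichlorophenyl but also differs on the core, and its value compared with that of compound 3 lies within the scatter. The expected step is therefore a 1.3-fold higher number from compound 3 to compound 4 (0.11 log units; within the scatter), none beyond the scatter. Compound 4 is estimated at 50 nM, within 22 nM to 120 nM.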

Compound 4, half-maximal inhibitory concentration: 41.8 nM
Estimate against measurement, compound 4: 1.2-fold (0.08 log units) above; measured number inside the range.
By their numbers in this assay, from the lowest: compounds 3, 2, 4 and 1 (each within the scatter of the next).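

In this assay, the change on the amine nitrogen in a ring can now be read directly: 3,5-dichlorophenyl in place of phenyl gives a 1.1-fold higher number from compound 3 to compound 4 (0.03 log units; within the scatter) and so does not separate the two compounds. 3,5-Dichlorophenyl in place of 3-cyanophenyl gives a 1.1-fold higher number from compound 2 to compound 4 (0.02 log units; within the scatter) on the same core, so phenyl, 3-cyanophenyl and 3,5-dichlorophenyl are not told apart at this position. On the core side, dropping the fluoro substituent gives a 1.4-fold lower number from compound 1 to compound 4 (0.16 log units; within the scatter) and also stays within the scatter, which separates this change from the piperazine substituent that compound 1 shares with compound 4.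

Going by these compounds, whether an amine or a carboxylic acid on this phenyl, or a longer chain in its place, would move the number beyond the scatter stays open. Nothing available bears on why these numbers lie so close together.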